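The compounds below may be only part of what the source reports. "The series", "measured", "known", "first", "only" and "open" are said of these compounds alone.

Compound 1, `C=CC(=O)Nc1cccc(-c2nc3ccccc3s2)c1`, in an ADME assay on HEK293 cells (Homo sapiens) for inhibition, with a stated time of 72 h (a lower number here means that less compound is needed, a higher number that more compound is needed for the effect), gives > 25000 nM, a limit of the assay. Compound 2, `CN(C)CCC(=O)Nc1cccc(-c2nc3ccccc3s2)c1`, gives > 25000 nM, also a limit. Compound 3, `O=C(CCl)Nc1cccc(-c2nc3ccccc3s2)c1`, gives 10000 nM.

Compound 2 thus stands at the upper edge of what this assay reports, sharing the limit of > 25000 nM in this assay, at which 2 of the 3 values shown sit, with compound 1, so no number is known for it. Compound 4, `O=C(Nc1cccc(-c2nc3ccccc3s2)c1)c1cnc(Cl)s1`, differs from compound 2 in one place: 2-chloro-1,3-thiazol-5-yl in place of 2-(dimethylamino)ethyl on a carbonyl carbon. Of the measured steps, the one most comparable is an at least 2.5-fold lower number from compound 2 to compound 3 (0.39 log units; beyond the scatter), where removing the basic chain gave a readable number. Within the data shown here, the step that the two limits leave unreadable from compound 1 to compound 2 stays unreadable, while an at least 2.5-fold lower number from compound 1 to compound 3 (0.39 log units; beyond the scatter) again points to the smaller, chlorine-bearing group as the one that reaches a number. Compound 4 also gives up the dimethylamino chain for a chlorine-bearing group, so a number near that of compound 3 is expected, though the limit remains likely. For compound 4 the expected value is 12000 nM, within 4000 nM to 25000 nM. This expectation corresponds to a step of an at least 2.0-fold lower number from compound 2 to compound 4 (0.31 log units; beyond the scatter).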

Compound 4, half-maximal effective concentration: > 25000 nM
Compound 4: a limit, no number; the forecaster's own chance of this, stated with the estimate: 50%; at least 2.0-fold (0.31 log units) between middle value and limit.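

In this assay compound 4 gives no number and joins compound 1 and compound 2 at the limit: the limit of > 25000 nM in this assay, at which 3 of the 4 values shown sit. Placing 2-chloro-1,3-thiazol-5-yl instead of chloromethyl on the carbonyl carbon gives an at least 2.5-fold higher number from compound 3 to compound 4 (0.39 log units; beyond the scatter), so among the compounds shown, a chlorine in the group at this position does not by itself go with a readable number, and compound 3 alone reaches one. The steps to compound 4 from compound 1 and from compound 2 have limits at both ends and cannot be read.

As far as these compounds go, how far compound 1, compound 2 and compound 4 lie beyond the limit stays open. So does whether a bromomethyl group or a longer chain ending in chlorine would give a number at this position.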